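Dinitrophenyl Replaces Methoxyphenyl on a Triazole Nitrogen

This account rests on a few compounds, and the source may have more. Where it says the series, first, only, none or still open, it means among the compounds named here.

Measured compounds:
- compound 1, `Cc1ccccc1-n1nncc1CN1C(=O)C2(C(C#N)=C(N)Oc3c2c2nc4ccccc4nc2c2ccccc32)c2ccccc21`, in a functional assay on A549 cells (Homo sapiens) for antiproliferative activity, read by MTT assay, with a stated time of 48 h; on this read-out lower numbers stand for stronger inhibition and higher numbers for weaker inhibition: > 50000 nM, which is a limit of the assay rather than a number
- compound 2, `COc1ccccc1-n1nncc1CN1C(=O)C2(C(C#N)=C(N)Oc3c(N)cc4nc5ccccc5nc4c32)c2ccccc21`, in this assay: 37500 nM

Among the compounds with values here, compound 2 holds the only actual number among the two measured compounds. Within the data shown here, compound 1 sits at the limit of > 50000 nM in this assay, at which 1 of the 2 values shown sits, so it gives no number that could be set against compound 2, and no step between two measured numbers can be read here.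

Compound 3, `N#CC1=C(N)Oc2c(N)cc3nc4ccccc4nc3c2C12C(=O)N(Cc1cnnn1-c1ccc([N+](=O)[O-])cc1[N+](=O)[O-])c1ccccc12`, has not yet been tested. It differs from compound 2 in one place: 2,4-dinitrophenyl in place of 2-methoxyphenyl on an aromatic nitrogen. The shared core and the rest of the molecule are unchanged.

Among the measured compounds shown here, with no measured step between compounds that differ in a single group, there is no basis for expecting a large move in either direction in this assay. The expectation is a step from compound 2 to compound 3 of a 1.1-fold lower number from compound 2 to compound 3 (0.03 log units; within the scatter), which is no step beyond the usual scatter. Compound 3 is therefore estimated at 35000 nM, within a range from 12000 nM to 100000 nM.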

Compound 3, half-maximal inhibitory concentration: > 50000 nM
Compound 3 was reported as a limit; the forecaster's own chance of this, stated with the estimate: 40%; middle value at least 1.4-fold (0.15 log units) away from the limit.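

Putting 2,4-dinitrophenyl in place of 2-methoxyphenyl on this aromatic nitrogen of the five-membered ring gives, in this assay, an at least 1.3-fold higher number from compound 2 to compound 3 (0.12 log units; that floor lies within the scatter). In this assay compound 3 gives > 50000 nM, which is a limit of the assay and not a number, so this step has only a floor and no measured size. This swap therefore brings no lower number at this position, and whether it costs any real activity stays unsettled, while compound 2 remains the only compound here with an actual number: the limit of > 50000 nM in this assay, at which 2 of the 3 values shown sit.

As far as these compounds go, the true value of compound 3 is unknown, and steps that involve compound 1 cannot be read. From the compounds shown here alone, whether a plain phenyl, or a phenyl carrying a single nitro group, an amine or a carboxylic acid, on this same nitrogen would give a number lower than that of compound 2 stays open.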